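Fluoro on the methanesulfonamido ring of compound 2

The source may hold more compounds than are shown below. What is called first, only, known or untested is meant among the compounds shown, and "the series" means these compounds.

Measured so far:
compound 1 `CCCCCCOc1cc(C(C)(C)C)ccc1C/N=C(\S)NCc1ccc(NS(C)(=O)=O)cc1` — 150 nM
compound 2 `CC(C)(C)C(=O)OCc1cc(C(C)(C)C)ccc1C/N=C(\S)NCc1ccc(NS(C)(=O)=O)cc1` — 70 nM

In a functional assay for inhibition of Vanilloid receptor (Rattus norvegicus) (on this read-out higher numbers stand for weaker inhibition and lower numbers for stronger inhibition), compound 2 gives 70 nM, the lowest of the two numbers; its nearest neighbour is compound 1, which in this assay gives 150 nM, and the step of a 2.1-fold lower number from compound 1 to compound 2 (0.33 log units; beyond the scatter) is beyond the scatter.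

Compound 3 `CC(C)(C)C(=O)OCc1cc(C(C)(C)C)ccc1C/N=C(\S)NCc1ccc(NS(C)(=O)=O)c(F)c1` differs from compound 2 in one place: fluoro in place of hydrogen on an aromatic carbon. Cut one bond further out, the change reads 4-(methanesulfonamido)phenyl to 3-fluoro-4-(methanesulfonamido)phenyl.

Among the compounds with values here, the single measured step, a 2.1-fold lower number from compound 1 to compound 2 (0.33 log units; beyond the scatter), concerns the hexyloxy position on the other ring and does not bear on fluoro in place of hydrogen on the methanesulfonamido ring. Within the data shown here, no measured step informs this change, so for compound 3 no step beyond the scatter is expected in this assay; the estimated step is a 1.3-fold lower number from compound 2 to compound 3 (0.10 log units; within the scatter), with a wide range. Compound 3 is estimated at 55 nM, between 20 nM and 160 nM.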

Compound 3, half-maximal inhibitory concentration: 15 nM
Compound 3: the middle estimate sits 3.7-fold (0.56 log units) above what was measured; the whole stated range lies above it.
By their numbers in this assay, from the lowest: compound 3; then compound 2; then compound 1.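

In this assay, fluoro in place of hydrogen ortho to the methanesulfonamido group gives a 4.7-fold lower number from compound 2 to compound 3 (0.67 log units; beyond the scatter), a step beyond the scatter. Within the data shown here, the earlier compounds differ only on the other ring, so this is the first reading on the methanesulfonamido ring, and it shows that the number responds to a single added fluorine atom at this position. No available evidence accounts for the size of this step.

As far as these compounds go, whether the response is specific to fluoro remains open; chloro, methyl or methoxy on the same aromatic carbon would test that. From the compounds shown here alone, it is also open whether the same change would lower the number with hexyloxy in place of the (((tert-butyl)carbonyl)oxy)methyl group, as in compound 1.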